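The source may report more compounds than this note shows. Statements on the series, on what has been measured and on what is new or still open speak of the compounds shown alone.

Compound 2 `CCc1cc(C(C)=O)c(O)cc1OCCCCCn1cncn1` carries a chain on its aromatic oxygen that ends in a triazole ring. In an assay on isolated protein for binding affinity to leukotriene B4 receptor 1 (Homo sapiens), tested at 1 uM (on this read-out higher numbers stand for more inhibition at the one concentration tested (going by the name of the read-out) and lower numbers for less inhibition), compound 2 gives 30%. Its nearest measured neighbour is compound 1 `CCc1cc(C(C)=O)c(O)cc1OCCCCC(C)(C)C#N`, which ends the same chain in a nitrile instead; in this assay compound 1 gives 30%, and the step of no change at the digits printed from compound 1 to compound 2 (within the scatter) lies within the scatter, so on the numbers shown compound 2 stands level with compound 1.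

Compound 3 `CCc1cc(C(C)=O)c(O)cc1OCCCCCCc1nnn[nH]1` is not yet measured. It differs from compound 2 in one place: (1H-tetrazol-5-yl)methyl in place of 1H-1,2,4-triazol-1-yl on a saturated chain carbon, five bonds along the chain from an oxygen on an aromatic ring. Going by the values given here, the only step that bears on this change is the one from compound 1 to compound 2, where the end of the chain was swapped between two unrelated groups without a shift beyond the scatter. The present swap again exchanges the chain end, and also lengthens the chain by one carbon. Among the compounds with values here, with only that one flat step as guidance, compound 3 is expected to sit near compound 2, the step of a number 5 percentage points higher from compound 2 to compound 3 (within the scatter) being small and of uncertain direction. The estimate for compound 3 in this assay is therefore 35%, with a range from 12% to 62%.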

Compound 3, a percentage reported as inhibition, at one concentration (the size of the read-out at that concentration, not a potency): 60%
For compound 3 the middle estimate is 25 percentage points below the measured one; low and high end bracket the measured number.
By their numbers in this assay, from the lowest: compounds 1 and 2 (each within the scatter of the next); then compound 3.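

In this assay, going by these compounds alone, this is the first real shift at the end of the chain: there is a number 30 percentage points higher from compound 2 to compound 3 (beyond the scatter) and also a number 30 percentage points higher from compound 1 to compound 3 (beyond the scatter) on the same read-out. The level pair of compound 1 and compound 2 could have suggested that the group placed here hardly matters, but compound 3, the highest of the three, shows that at least one change at this position can move the number. The entering group carries 1 hydrogen-bond donor where the leaving group carries 0, yet nothing shown here explains the rise.

Because the change from compound 2 to compound 3 swaps the ring and lengthens the chain together, the compounds shown cannot say which of the two matters, and a 1H-1,2,4-triazol-1-yl group on the longer chain or a 1H-tetrazol-5-yl group on the shorter one would separate them. It also remains open how a carboxylic acid at the chain end or a still longer chain would read, and a percentage at one concentration gives no potency for any of these compounds.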